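Compound 2 and one exchanged group

This account rests on a few compounds, and the source may have more. Where it says the series, first, only, none or still open, it means among the compounds named here.

Compound 1 `Cc1ccc(-c2cc(C(=O)N[C@H](C)c3ccc(C(F)(F)F)[n+]([O-])c3)cc(C(C)(C)O)c2)nc1` measured 62.4%
Compound 2 `Cc1ccc(-c2cc(C(=O)N[C@H](C)c3nc(C)no3)cc(-c3ncccc3F)c2)nc1` measured 99.6%

In an ADME assay on a cell-free system (plasma, Rattus norvegicus) for protein binding, compound 2 has the lower unbound fraction of the two compounds, and its gap to compound 1 lies beyond the scatter. The next compound, compound 3 `Cc1ccc(-c2cc(C(=O)N[C@H](C)c3ccc(F)cn3)cc(-c3ncccc3F)c2)nc1`, carries 5-fluoropyridin-2-yl in place of 3-methyl-1,2,4-oxadiazol-5-yl on a saturated chain carbon bound to an amide-type nitrogen and a saturated chain carbon. Going by the values given here, no two measured compounds differ in one place only, so no measured step speaks directly to this exchange. The expectation therefore starts from compound 2 (99.6%), whose other parts compound 3 keeps, and no change beyond the scatter is expected in this assay. The estimated move, a slight one towards a higher unbound fraction, is a 1.5-fold higher unbound fraction from compound 2 to compound 3 (0.18 log units; within the scatter) and would stay within the scatter. Compound 3 is estimated at 99.4% (expected range 98.5% to 99.8%).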

Compound 3, plasma protein binding: 99.2%
Compound 3: the middle estimate sits 1.3-fold (0.12 log units) (unbound fraction) below what was measured; measured number inside the range.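

In this assay, 5-fluoropyridin-2-yl in place of 3-methyl-1,2,4-oxadiazol-5-yl on a saturated chain carbon bound to an amide-type nitrogen and a saturated chain carbon gives a 2.0-fold higher unbound fraction from compound 2 to compound 3 (0.30 log units; within the scatter), and this is the first pair shown that differs in one place only. At this position, a five-membered aromatic ring with 3 hetero atoms and 3 hydrogen-bond acceptors and a six-membered aromatic ring with 1 hetero atom and 1 hydrogen-bond acceptor therefore cannot be told apart by this read-out, since the step stays within the scatter. No measurement at hand offers an explanation for this result.

Going by these compounds, both compounds of this pair keep the same remaining structure and are almost entirely bound, so it stays open whether the same exchange would also stay within the scatter on a different core or on a compound with a much larger unbound fraction. On these data alone, it also stays open whether a carboxylic acid or an amine at this place, instead of an aromatic ring, would move the unbound fraction beyond the scatter.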